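From compound 2 to compound 3: a new carbonyl substituent

A few compounds are considered here, and "the series" means these few. Any claim that something is new, unique, unknown or untested is made for them only; others in the source may bear on it.

In a functional assay on MCF7 cells (Homo sapiens) for antiproliferative activity, read by MTT assay, with a stated time of 48 h (on this read-out lower numbers stand for stronger inhibition and higher numbers for weaker inhibition), compound 1 (`Cc1c(C(=O)NCCCN(C)C)oc2ccc(N(Cc3ccc(Br)cc3)S(=O)(=O)c3ccc(Br)cc3)cc12`) gives 3710 nM, while compound 2 (`Cc1c(C(=O)OCCCN(C)C)oc2ccc(N(Cc3ccc(Br)cc3)S(=O)(=O)c3ccc(Br)cc3)cc12`) gives 39700 nM, the higher of the two numbers. Compound 3 (`Cc1c(C(=O)NCCS(C)(=O)=O)oc2ccc(N(Cc3ccc(Br)cc3)S(=O)(=O)c3ccc(Br)cc3)cc12`) carries (2-(methylsulfonyl)ethyl)amino in place of 3-(dimethylamino)propoxy on a carbonyl carbon. Among the compounds with values here, the only measured step bearing on this shows an 11-fold higher number from compound 1 to compound 2 (1.03 log units; beyond the scatter), a large change on introducing 3-(dimethylamino)propoxy. Read backwards, it points to a lower number, but no measured step covers the new chain. A smaller drop is therefore expected in this assay, with a 4.0-fold lower number from compound 2 to compound 3 (0.60 log units; beyond the scatter) as the estimated step. The estimated value for compound 3 is 10000 nM, within an expected range of 3000 nM to 35000 nM.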

Compound 3, half-maximal inhibitory concentration: > 40000 nM
Compound 3: no number, only a limit (the forecaster's own chance of this, stated with the estimate: 8%); middle value at least 4.0-fold (0.60 log units) away from the limit.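

In this assay, compound 3 gives only a limit of the assay, not a number: the limit of > 40000 nM in this assay, at which 1 of the 3 values shown sits. The new carbonyl substituent gives a number no lower from compound 2 to compound 3 (the limit leaves the size open), so the size of this step cannot be read. An amide link on this carbonyl carbon therefore does not by itself keep the number low: methylsulfonyl in place of (dimethylamino)methyl gives an at least 10-fold higher number from compound 1 to compound 3 (1.03 log units; beyond the scatter).

Going by these compounds, what remains open is how much depends on the dimethylamino group itself. On these data alone, how an amide chain ending in a primary amine or a carboxylic acid, or a longer chain, would read in this assay is unknown.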